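Swapping the Aryl Halogen: Fluoro to Bromo

The source may hold more compounds than are shown below. What is called first, only, known or untested is meant among the compounds shown, and "the series" means these compounds.

Compounds measured in a functional assay on NCI-H460 cells (Homo sapiens) for antiproliferative activity, read by MTT assay, with a stated time of 48 h; on this read-out higher numbers stand for weaker inhibition and lower numbers for stronger inhibition:
compound 1 `CC1(C)Cc2c(OCc3ccccc3)ccc(C(=O)/C=C/c3ccccc3)c2O1` gives > 100000 nM, a limit of the assay.
compound 2 `CC1(C)Cc2c(OCc3ccccc3)ccc(C(=O)/C=C/c3ccc(F)cc3)c2O1` gives 22300 nM.
compound 3 `CC1(C)Cc2c(OCc3ccccc3)ccc(C(=O)/C=C/c3cn(-c4ccccc4)nc3-c3ccc([N+](=O)[O-])cc3)c2O1` gives > 100000 nM, a limit of the assay.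

For the measured compounds named here, compound 2 stands as the only real number among the three values; the other two sit at the limit of > 100000 nM in this assay, at which 2 of the 3 values shown sit. The step from compound 1 to compound 2 is an at least 4.4-fold lower number from compound 1 to compound 2 (0.65 log units; beyond the scatter), so a halogen on the aromatic carbon moves the read-out by at least a modest margin. Compound 4 `CC1(C)Cc2c(OCc3ccccc3)ccc(C(=O)/C=C/c3ccc(Br)cc3)c2O1` carries the change (bromo in place of fluoro on an aromatic carbon). Going by the values given here, the only measured step that bears on it is an at least 4.4-fold lower number from compound 1 to compound 2 (0.65 log units; beyond the scatter); it shows that a halogen at this carbon helps, but no measured pair tells how bromo compares with fluoro. Compound 4 is therefore expected to land close to compound 2, with an estimated step of a 1.9-fold lower number from compound 2 to compound 4 (0.27 log units; within the scatter) toward a lower number. The estimate for compound 4 is 12000 nM, with a range from 4000 nM to 40000 nM.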

Compound 4, half-maximal inhibitory concentration: > 100000 nM
Compound 4 ended at the assay's limit; the forecaster's own chance of this, stated with the estimate: 10%; middle value at least 8.3-fold (0.92 log units) away from the limit.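

In this assay, putting bromo in place of fluoro gives an at least 4.4-fold higher number from compound 2 to compound 4 (0.65 log units; beyond the scatter), so the gain seen with fluoro does not extend to the other halogen tested at this carbon. Of the three groups shown on this aromatic carbon (hydrogen, fluoro and bromo), only fluoro gives a real number, and this holds even though the swap exchanges one heavy atom for one heavy atom. The steps from compound 1 to compound 4 cannot be read, as both compounds sit at a limit: the limit of > 100000 nM in this assay, at which 3 of the 4 values shown sit.

As far as these compounds go, whether a chloro or a methoxy group on this carbon would give a real number remains open. From the compounds shown here alone, the true size of the step to compound 4 also stays open, as the value of compound 4 is only a limit.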